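The source may hold more compounds than are shown below. What is called first, only, known or untested is meant among the compounds shown, and "the series" means these compounds.

Measured so far in a physicochemical assay for solubility; on this read-out higher numbers stand for higher solubility and lower numbers for lower solubility:
Compound 1 `COC(=O)c1ccc(NC(=O)c2cc3cc([N+](=O)[O-])ccc3s2)cc1` gives 10 ug/mL.
Compound 2 `NC(=O)c1cccc(NC(=O)c2cc3ccccc3s2)c1` reaches only a limit of the assay, < 5 ug/mL.
Compound 3 `NC(=O)c1cccc(NC(=O)c2ccc3ccccc3n2)c1` gives 10 ug/mL.

Compound 2 thus stands at the lower edge of the numbers shown, (the limit of < 5 ug/mL in this assay, at which 1 of the 3 values shown sits), and no number is known for it beyond that limit. Compound 4 `NC(=O)c1cccc(NC(=O)c2cc3cc([N+](=O)[O-])ccc3s2)c1` differs from it by nitro in place of hydrogen on an aromatic carbon. Within the data shown here, no measured pair in the set differs in this one place, so the size of the step is not anchored. Compound 1, which carries the same nitro on the same core, sits at a measurable value, so a small upward step in this assay is expected, not beyond the scatter. Compound 4 is estimated at 6 ug/mL, within 2 ug/mL to 15 ug/mL. This expected step is an at least 1.2-fold higher number from compound 2 to compound 4 (0.07 log units; that floor lies within the scatter).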

Compound 4, solubility: 25 ug/mL
The estimate for compound 4 lay 4.2-fold (0.62 log units) below the measured number, and the stated range ends below it.
By their numbers in this assay, from the lowest: compounds 1 and 3 (each within the scatter of the next); then compound 4. At a limit, below all of these: compound 2.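

In this assay, among these compounds, nitro in place of hydrogen on an aromatic carbon gives the only readable step at this position in the set (an at least 5.0-fold higher number from compound 2 to compound 4 (0.69 log units; beyond the scatter)), and that step lies beyond the scatter. The printed step is a floor and not a full size, since compound 2 stands at a limit of the assay: (the limit of < 5 ug/mL in this assay, at which 1 of the 4 values shown sits).

From the compounds shown here alone, whether an amine or a carboxylic acid on the same aromatic carbon would give a step of similar size remains open. Also open, going by these compounds, is whether nitro gives such a step on any other core.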